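Sulfamoylurea series: amide aryl change from compound 1

The source may report more compounds than this note shows. Statements on the series, on what has been measured and on what is new or still open speak of the compounds shown alone.

Measured so far:
compound 1 `O=C(NC1CCCCC1)NS(=O)(=O)N1CCC(CCNC(=O)c2cscn2)CC1` — 23%
compound 2 `CCCNC(=O)NS(=O)(=O)N1CCC(CCNC(=O)c2cscn2)CC1` — 10%

Within the data shown here, compound 1 holds the higher of the two numbers in a functional assay on the whole organism (blood) with Rattus norvegicus as the target, with stated times of 24 h and 1 h, at a dose of 5 mg/kg by the intraperitoneal route; on this read-out higher numbers stand for a stronger effect at the one dose given and lower numbers for a weaker effect; the one step measured, a number 13 percentage points lower from compound 1 to compound 2 (beyond the scatter), replaces the group on an amide-type nitrogen. Compound 3 `O=C(NC1CCCCC1)NS(=O)(=O)N1CCC(CCNC(=O)c2ccnc3ccccc23)CC1` differs from compound 1 by quinolin-4-yl in place of 1,3-thiazol-4-yl on a carbonyl carbon. Among the measured compounds shown here, that measured step leaves the group on the carbonyl carbon untouched, so it gives no guide to this change, and no other compound varies that group. With nothing to rest on, a change no larger than the scatter is expected, a number 2 percentage points higher from compound 1 to compound 3 (within the scatter). For compound 3 the estimate is 25%, with a range from 5% to 50%.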

Compound 3, a percentage reported as activity, at one dose (the size of the read-out at that dose, not a potency): 16%
Compound 3: the middle estimate sits 9 percentage points above what was measured; measured number inside the range.
By their numbers in this assay, from the lowest: compounds 2, 3 and 1 (each within the scatter of the next, the first and the last beyond it).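

In this assay, among these compounds, the group on the carbonyl carbon now varies for the first time: quinolin-4-yl in place of 1,3-thiazol-4-yl gives a number 7 percentage points lower from compound 1 to compound 3 (within the scatter). At this one dose, the read-out therefore does not separate a single five-membered ring from the two six-membered rings of quinolin-4-yl. No measurement available here bears on this result.

Open, as far as these compounds go, is whether a phenyl or a simple alkyl chain on the carbonyl carbon would read outside the scatter. Also open, from the compounds shown here alone, is whether propyl on the amide-type nitrogen would give the same step with quinolin-4-yl on the carbonyl carbon.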